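The source may report more compounds than this note shows. Statements on the series, on what has been measured and on what is new or still open speak of the compounds shown alone.

Compound 1 `CNc1nccc(N2CC[C@H](NC(=O)Nc3ccc(OC)cc3)C2)n1` has the highest number of the two compounds measured in an assay on a protein complex for displacement of a labelled ligand from CDK8/Cyclin C (Homo sapiens), read by TR-FRET, with a stated time of 1 h (on this read-out higher numbers stand for weaker inhibition and lower numbers for stronger inhibition), with compound 1 giving 7160 nM. Its nearest neighbour is compound 2 `CNc1nccc(N2CC[C@H](NC(=O)Nc3ccc(OC(F)F)cc3)C2)n1`, which in this assay gives 143 nM, a change of a 50-fold lower number from compound 1 to compound 2 (1.70 log units; beyond the scatter). Compound 3 `CNc1nccc(N2CC[C@H](NC(=O)Nc3cccc(OC)c3)C2)n1` differs from compound 1 in where the methoxy group sits: 3-methoxyphenyl in place of 4-methoxyphenyl on an amide-type nitrogen. Among the compounds with values here, the one measured step swaps the group itself rather than its place on the ring, so it offers no direct guide here. With nothing pointing either way, compound 3 is expected to stay close to compound 1, a step of a 1.0-fold lower number from compound 1 to compound 3 (0.01 log units; within the scatter), that is an estimated 7000 nM, within 2500 nM to 20000 nM.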

Compound 3, half-maximal inhibitory concentration: 3620 nM
Estimate against measurement, compound 3: 1.9-fold (0.29 log units) above; the measured number falls inside the stated range.
By their numbers in this assay, from the lowest: compound 2; then compounds 3 and 1 (each within the scatter of the next).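

Moving the methoxy group from 4-methoxyphenyl to 3-methoxyphenyl on the amide-type nitrogen gives a 2.0-fold lower number from compound 1 to compound 3 (0.30 log units; within the scatter) in this assay, so the two placements cannot be told apart. This step is much smaller than a 50-fold lower number from compound 1 to compound 2 (1.70 log units; beyond the scatter), the swap of methyl for difluoromethyl on the oxygen. Nothing available here explains either step. Open, from the compounds shown here alone, is whether difluoromethyl on the oxygen would give a similar step with the oxygen placed as in compound 3. Also open, going by these compounds, is how an ethoxy group, an amine or a carboxylic acid would compare on this ring.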